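Swapping the aryl group on the saturated ring carbon

A few compounds are considered here, and "the series" means these few. Any claim that something is new, unique, unknown or untested is made for them only; others in the source may bear on it.

Compound 1 `CC(=O)N1N=C(c2ccc(-n3nc(C)n(N)c3=O)cc2)CC1c1ccc(C)cc1` and compound 2 `CC(=O)N1N=C(c2ccc(-n3nc(C)n(N)c3=O)cc2)CC1c1ccccc1Cl` share one core and differ only in the aryl group on a saturated ring carbon. Among the measured compounds shown here, in an assay on isolated protein for inhibition of pancreatic alpha-amylase (Homo sapiens), with a stated time of 10 min, tested at 1 mg/mL (a higher number here means more inhibition at the concentration tested (going by the name of the read-out), a lower number less inhibition), compound 1 gives 96.5%, while compound 2 gives 76.7%, the lower of the two numbers; the step of a number 19.8 percentage points lower from compound 1 to compound 2 (beyond the scatter) is the only measured step here. Compound 3 `CC(=O)N1N=C(c2ccc(-n3nc(C)n(N)c3=O)cc2)CC1c1ccc(O)cc1` is not yet measured; it differs from compound 2 by 4-hydroxyphenyl in place of 2-chlorophenyl on a saturated ring carbon. For the measured compounds named here, the single step suggests a change of aryl group at this position can matter modestly, so a rise toward compound 1 is expected, a number 11.3 percentage points higher from compound 2 to compound 3 (beyond the scatter). Compound 3 is therefore estimated at 88%, between 72% and 99%.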

Compound 3, a percentage reported as inhibition, at one concentration (the size of the read-out at that concentration, not a potency): 76.7%
The estimate for compound 3 lay 11.3 percentage points above the measured number; measured number inside the range.
By their numbers in this assay, from the lowest: compounds 2 and 3 (each within the scatter of the next); then compound 1.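

In this assay 4-hydroxyphenyl in place of 2-chlorophenyl on the saturated ring carbon gives no change at the digits printed from compound 2 to compound 3 (within the scatter) and so does not separate these two aryl groups. Hydroxy in place of methyl on the aromatic carbon gives a number 19.8 percentage points lower from compound 1 to compound 3 (beyond the scatter) and shows that a single change on this aryl ring can register beyond the scatter. Nothing available explains either result. On these data alone, whether an aminophenyl or a carboxyphenyl group at this position would read closer to compound 1 or to compound 3 remains open.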